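The source may hold more compounds than are shown below. What is called first, only, known or untested is meant among the compounds shown, and "the series" means these compounds.

Three anilides of a shared core have been measured in a functional assay on HeLa cells (Homo sapiens) for inhibition, read by MTT assay, with a stated time of 48 h; on this read-out lower numbers stand for stronger inhibition and higher numbers for weaker inhibition. Compound 1 `COc1ccc2c(=O)c(/C=C/C(=O)Nc3ccccc3Cl)coc2c1` gives 22400 nM, and compound 2 `COc1cccc(NC(=O)/C=C/c2coc3cc(OC)ccc3c2=O)c1` gives 19200 nM; the step of a 1.2-fold lower number from compound 1 to compound 2 (0.07 log units; within the scatter) stays within the scatter. Compound 3 `COc1ccc2c(=O)c(/C=C/C(=O)Nc3ccccc3C)coc2c1` gives 7270 nM, the lowest of the three numbers, set apart from the other two by the steps of a 3.1-fold lower number from compound 1 to compound 3 (0.49 log units; beyond the scatter) and a 2.6-fold lower number from compound 2 to compound 3 (0.42 log units; beyond the scatter), both modest.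

Compound 4 `COc1ccc2c(=O)c(/C=C/C(=O)Nc3ccc(C)cc3)coc2c1` differs from compound 3 by one change: 4-methylphenyl in place of 2-methylphenyl on an amide-type nitrogen. Among the compounds with values here, none of the measured steps repeats this exact change. The step from compound 1 to compound 2 moved a substituent to another position of the phenyl while also exchanging it, and stayed within the scatter; the two steps that went beyond the scatter both ended at compound 3 and involved a different group, not a shift of the methyl. Within the data shown here, no step therefore argues for a change of a particular direction, and compound 4 is expected to stay within the scatter of compound 3, the estimated step being a 1.3-fold higher number from compound 3 to compound 4 (0.12 log units; within the scatter). The estimate for compound 4 in this assay is 9500 nM, with a range from 3500 nM to 26000 nM.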

Compound 4, half-maximal inhibitory concentration: 24100 nM
Estimate against measurement, compound 4: 2.5-fold (0.40 log units) below; measured number inside the range.
By their numbers in this assay, from the lowest: compound 3; then compounds 2, 1 and 4 (each within the scatter of the next).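

In this assay, within the data shown here, the place of the methyl on the phenyl turns out to matter: 4-methylphenyl in place of 2-methylphenyl on the amide-type nitrogen gives a 3.3-fold higher number from compound 3 to compound 4 (0.52 log units; beyond the scatter) and is the only step here that shifts a group without exchanging it. Compound 4 is not separated from the other two anilides, with a 1.3-fold higher number from compound 2 to compound 4 (0.10 log units; within the scatter) and a 1.1-fold higher number from compound 1 to compound 4 (0.03 log units; within the scatter) both within the scatter, so compound 3 alone stands apart as the strongest of the four, while compound 1, with 2-chlorophenyl, shows that a substituent at that place does not by itself bring the lower number. No measurement at hand offers an explanation for this difference.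

The compounds shown leave open whether the lower number is tied to the methyl itself, since an ethyl group, a longer chain or an amine at the same place on the phenyl does not appear among them. They also leave open whether the gap between the 2-methylphenyl and the 4-methylphenyl would hold outside these cells.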